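A Sulfonyl Aryl Swap on Compound 2

This account rests on a few compounds, and the source may have more. Where it says the series, first, only, none or still open, it means among the compounds named here.

Of the compounds shown here, two have been measured so far: compound 1 (`Cc1ccc(C)c(S(=O)(=O)n2c(-c3cn(-c4ccccc4)nc3-c3ccc(F)cc3)nc3ccccc32)c1`) and compound 2 (`COc1ccc(S(=O)(=O)n2c(-c3cn(-c4ccccc4)nc3-c3ccc(C(F)(F)F)cc3)nc3ccccc32)cc1`). In a functional assay on HepG2 cells (Homo sapiens) for antiproliferative activity, read by MTT assay, with a stated time of 24 h (on this read-out lower numbers stand for stronger inhibition and higher numbers for weaker inhibition), compound 1 gives 410 nM and compound 2 gives 370 nM so compound 2 stands level with compound 1 within the usual scatter. Compound 3 (`Cc1ccc(C)c(S(=O)(=O)n2c(-c3cn(-c4ccccc4)nc3-c3ccc(C(F)(F)F)cc3)nc3ccccc32)c1`) has yet to be measured. It differs from compound 2 by 2,5-dimethylphenyl in place of 4-methoxyphenyl on a sulfonyl sulfur. Among the compounds with values here, no measured step isolates this change. Compound 1 also carries 2,5-dimethylphenyl on a sulfonyl sulfur and gives 410 nM in this assay and this value offers no reason to expect a clear shift in either direction. The expected change is a 1.1-fold higher number from compound 2 to compound 3 (0.03 log units; within the scatter) and it is estimated to stay within the scatter. Compound 3 is expected at 400 nM with an estimated range from 190 nM to 850 nM in this assay when tested.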

Compound 3, half-maximal inhibitory concentration: 330 nM
The estimate for compound 3 lay 1.2-fold (0.08 log units) above the measured number; the measured number falls inside the stated range.
By their numbers in this assay, from the lowest: compounds 3, 2 and 1 (each within the scatter of the next).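

In this assay, placing 2,5-dimethylphenyl in place of 4-methoxyphenyl on a sulfonyl sulfur gives a 1.1-fold lower number from compound 2 to compound 3 (0.05 log units; within the scatter), so at this position the two aryl groups cannot be told apart, even though the hydrogen-bond acceptor counted on 4-methoxyphenyl is gone. With 2,5-dimethylphenyl held on the sulfonyl sulfur, trifluoromethyl in place of fluoro on an aromatic carbon gives a 1.2-fold lower number from compound 1 to compound 3 (0.09 log units; within the scatter), so that change also leaves the number within the scatter. Nothing available bears on why these numbers lie so close together.

The compounds shown leave open whether an amine or a carboxylic acid on the aryl group at the sulfonyl sulfur would move the number beyond the scatter. They also leave open what a simple ethyl chain in place of that aryl group would do.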